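The source may hold more compounds than are shown below. What is called first, only, known or untested is meant among the compounds shown, and "the series" means these compounds.

Measured in a functional assay on HCT-116 cells (Homo sapiens) for antiproliferative activity, read by CellTiter-Glo, with a stated time of 72 h; a higher number here means a weaker inhibitor, a lower number a stronger inhibitor:
Compound 1 `Cc1ccc(-c2cncc(/C=C/c3ccc(C(=O)NO)cc3)c2)cc1`: > 10000 nM (a limit)
Compound 2 `O=C(NO)c1ccc(/C=C/c2cncc(-c3ccccc3O)c2)cc1`: 4680 nM

Within the data shown here, compound 2 holds the only actual number in this assay, at 4680 nM. The entry for compound 1, > 10000 nM, is a limit of the assay and not a number.

Compound 3 `COc1ccc(F)cc1-c1cncc(/C=C/c2ccc(C(=O)NO)cc2)c1`, not yet measured, has 5-fluoro-2-methoxyphenyl in place of 2-hydroxyphenyl on the same aromatic carbon: 5-fluoro-2-methoxyphenyl in place of 2-hydroxyphenyl on an aromatic carbon. Among the measured compounds shown here, one measured step bears on this place: an at least 2.1-fold lower number from compound 1 to compound 2 (0.32 log units; beyond the scatter). That step brought in the 2-hydroxyphenyl group that now leaves, so some return toward a higher number is expected, though perhaps not beyond the scatter. The expected change is a 1.4-fold higher number from compound 2 to compound 3 (0.14 log units; within the scatter). In this assay the estimate for compound 3 is 6500 nM, with an estimated range from 2500 nM to 10000 nM.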

Compound 3, half-maximal inhibitory concentration: 3410 nM
Estimate against measurement, compound 3: 1.9-fold (0.28 log units) above, and the stated range covers the measured number.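

In this assay, the aromatic carbon two atoms from the ring nitrogen accepts 5-fluoro-2-methoxyphenyl in place of 2-hydroxyphenyl, with 0 hydrogen-bond donors on the entering group, and the result is a 1.4-fold lower number from compound 2 to compound 3 (0.14 log units; within the scatter). Across these compounds, then, a hydrogen-bond donor on this ring is not needed to stay clear of the 4-methylphenyl compound, as the second step shows: an at least 2.9-fold lower number from compound 1 to compound 3 (0.46 log units; beyond the scatter). That step starts from compound 1, whose entry is a limit of the assay and not a number: the limit of > 10000 nM in this assay, at which 1 of the 3 values shown sits.

The compounds shown leave open how the methoxy and the fluorine of 5-fluoro-2-methoxyphenyl each count on their own. They also leave open how an amine or a carboxylic acid on this ring would read in this assay.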